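Chain extension on the shared core against alpha-glucosidase

This account rests on a few compounds, and the source may have more. Where it says the series, first, only, none or still open, it means among the compounds named here.

Working notes. Three measured compounds share one core: compound 1 `CC[C@@H]1N[C@@H](CO)[C@H](O)[C@H]1O`, compound 2 `CCC[C@@H]1N[C@@H](CO)[C@H](O)[C@H]1O` and compound 3 `CCCCCCC[C@@H]1N[C@@H](CO)[C@H](O)[C@H]1O`. In an assay on isolated protein (strain Wistar) for inhibition of lysosomal alpha-glucosidase (Rattus norvegicus), with a stated time of 30 min (a higher number here means a weaker inhibitor, a lower number a stronger inhibitor), compound 1 gives 2600 nM, compound 2 gives 1700 nM and compound 3 gives 380 nM, the lowest number of the three. Compound 4 `CCCCCCCCCC[C@@H]1N[C@@H](CO)[C@H](O)[C@H]1O` differs from compound 3 by propyl in place of hydrogen on a saturated chain carbon, seven bonds along the chain from a saturated ring carbon. All measured steps bear on this, each being a chain lengthening: a 1.5-fold lower number from compound 1 to compound 2 (0.18 log units; within the scatter), a 6.8-fold lower number from compound 1 to compound 3 (0.84 log units; beyond the scatter) and a 4.5-fold lower number from compound 2 to compound 3 (0.65 log units; beyond the scatter). The shortest addition gave nothing beyond the scatter, the longer ones modest gains. For compound 4 a further modest lowering is therefore expected, a 2.5-fold lower number from compound 3 to compound 4 (0.40 log units; beyond the scatter). Compound 4 is estimated at 150 nM, within a range from 50 nM to 500 nM.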

Compound 4, half-maximal inhibitory concentration: 1200 nM
Compound 4: the middle estimate sits 8.0-fold (0.90 log units) below what was measured, and the stated range ends below it.
By their numbers in this assay, from the lowest: compound 3; then compounds 4, 2 and 1 (each within the scatter of the next, the first and the last beyond it).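

For the compounds shown here, at this position, lengthening stops paying: propyl in place of hydrogen, seven bonds along the chain from a saturated ring carbon, gives a 3.2-fold higher number from compound 3 to compound 4 (0.50 log units; beyond the scatter) in this assay and is the first step to raise the number beyond the scatter. The response to chain length is therefore not steady, and among the four compounds the lowest number belongs to compound 3. No measurement at hand accounts for this reversal. Where the turn lies among chains intermediate between those of compound 3 and compound 4 remains open. Also open, as far as these compounds go, is whether a hydroxyl or an amine at the end of the longer chain would change the outcome.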